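A few compounds are considered here, and "the series" means these few. Any claim that something is new, unique, unknown or untested is made for them only; others in the source may bear on it.

Compound 1 `CCCCOc1ccc(C(=O)NNc2c(Br)cccc2Br)cc1`: > 100000 nM (a limit of the assay)
Compound 2 `O=C(NNc1c(Br)cccc1Br)c1ccc(-c2ccccc2)cc1`: 84100 nM

These two compounds were tested in a toxicity assay on MDCK cells (Canis lupus familiaris) for cytotoxicity, read by CCK-8 assay, with a stated time of 48 h; a higher number here means that more compound is tolerated, a lower number that less compound is tolerated. Within the data shown here, compound 2 gives 84100 nM, the only actual number so far. Compound 1 gives > 100000 nM, which is a limit and not a number.

The next compound, compound 3 `CCN(CC)c1ccc(C(=O)NNc2c(Br)cccc2Br)cc1`, has diethylamino in place of phenyl on an aromatic carbon of compound 2: diethylamino in place of phenyl on an aromatic carbon.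

Among the measured compounds shown here, one measured step bears on this change, since it involves the same place on the shared core: an at least 1.1-fold lower number from compound 1 to compound 2 (0.07 log units; that floor lies within the scatter). That step starts from the limit of > 100000 nM in this assay, at which 1 of the 2 values shown sits, so its true size is not known. For the measured compounds named here, it shows no change beyond the scatter, and it is the only guide available. No step beyond the scatter is therefore expected in this assay, and compound 3 may well reach the limit of the assay. The expected result is a 1.1-fold higher number from compound 2 to compound 3 (0.03 log units; within the scatter). For compound 3 the estimated value is 90000 nM, with an expected range from 40000 nM to 150000 nM.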

Compound 3, half-maximal cytotoxic concentration: 34000 nM
Compound 3: the middle estimate sits 2.6-fold (0.42 log units) above what was measured; the whole stated range lies above it.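

In this assay, among these compounds, this position, on an aromatic carbon and para to a large group, turns out to respond to the choice of substituent: diethylamino in place of phenyl gives a 2.5-fold lower number from compound 2 to compound 3 (0.39 log units; beyond the scatter), the first step that clearly exceeds the scatter. Diethylamino in place of butoxy points the same way, with an at least 2.9-fold lower number from compound 1 to compound 3 (0.46 log units; beyond the scatter), so compound 3 has the lowest number of the three and is the least tolerated of them. That second step is only a floor and its true size is not known, because compound 1 carries a limit and not a number: the limit of > 100000 nM in this assay, at which 1 of the 3 values shown sits.

The compounds shown leave open whether the lower number goes with the nitrogen attached to the ring or with the two ethyl chains, a question that a dimethylamino group, a piperidine ring or a plain butyl chain at this position could help to separate. They also leave open whether a morpholine ring or a carboxylic acid here would keep the number as low as in compound 3 or return it to the level of the other two compounds.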